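The compounds below may be only part of what the source reports. "The series", "measured", "known", "first", "only" and "open" are said of these compounds alone.

Series notes. Compound 1 `COc1cc(-c2cc(/C=C/C(=O)c3ccc(N)cc3)[nH]n2)cc(OC)c1OC` gives 79% in a functional assay on SNB-19 cells (Homo sapiens) for cytotoxicity, read by sulforhodamine B assay, with a stated time of 48 h, tested at 1 uM; on this read-out lower numbers stand for a stronger effect and higher numbers for a weaker effect at the one concentration tested. Among the measured compounds shown here, compound 2 `COc1cc(-c2cc(/C=C/C(=O)c3ccc(Cl)c(Cl)c3)[nH]n2)cc(OC)c1OC` gives 90% in this assay, the highest of the two numbers so far; the only measured step is a number 11 percentage points higher from compound 1 to compound 2 (beyond the scatter). Compound 3 `COc1ccc(C(=O)/C=C/c2cc(-c3cc(OC)c(OC)c(OC)c3)n[nH]2)cc1OC` differs from compound 2 by 3,4-dimethoxyphenyl in place of 3,4-dichlorophenyl on a carbonyl carbon. For the measured compounds named here, no measured step swaps one substituted phenyl for another on a carbonyl carbon, so the single step gives little guidance on direction. The step of a number 5 percentage points lower from compound 2 to compound 3 (within the scatter) is expected to stay within the scatter. The estimate for compound 3 in this assay is 85%, with a range from 70% to 100%.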

Compound 3, a percentage reported as activity, at one concentration (the size of the read-out at that concentration, not a potency): 73%
For compound 3 the middle estimate is 12 percentage points above the measured one; low and high end bracket the measured number.
By their numbers in this assay, from the lowest: compounds 3 and 1 (each within the scatter of the next); then compound 2.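

The phenyl group on a carbonyl carbon clearly matters in this assay: a number 17 percentage points lower from compound 2 to compound 3 (beyond the scatter), so 3,4-dimethoxyphenyl and 3,4-dichlorophenyl are not interchangeable at this place. Among the compounds shown here, the second new step, a number 6 percentage points lower from compound 1 to compound 3 (within the scatter), puts 3,4-dimethoxyphenyl level with 4-aminophenyl, leaving 3,4-dichlorophenyl as the one group apart from the other two. Nothing available explains this difference.

Going by these compounds, whether a carboxylic acid on that phenyl, or a plain alkyl chain in its place, would lower the number remains open. Readings at one concentration show only a stronger or weaker effect at that concentration for all three compounds.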